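The source may hold more compounds than are shown below. What is called first, only, known or untested is meant among the compounds shown, and "the series" means these compounds.

Measured so far:
Compound 1, `NC(=O)c1cn([C@@H]2O[C@H](CO)[C@@H](O)[C@H]2O)nn1`: > 200000 nM
Compound 2, `COc1ccc(-c2cn([C@@H]3O[C@H](CO)[C@@H](O)[C@H]3O)nn2)cc1`: 152000 nM

In a functional assay on L1210 cells (Mus musculus) (on this read-out higher numbers stand for weaker inhibition and lower numbers for stronger inhibition), compound 1 reaches only a limit, > 200000 nM, not a number, as the limit of > 200000 nM in this assay, at which 1 of the 2 values shown sits, records. Among the measured compounds shown here, compound 2 gives the single measured number, 152000 nM, which is very weak inhibition. Compound 3, `OC[C@H]1O[C@@H](n2cc(-c3ccc(F)cc3)nn2)[C@H](O)[C@@H]1O`, differs from compound 2 by fluoro in place of methoxy on an aromatic carbon. For the measured compounds named here, with no measured step to lean on, the change is expected to stay within the scatter, so a 1.1-fold higher number from compound 2 to compound 3 (0.02 log units; within the scatter) is the expectation. Compound 3 is therefore estimated at 160000 nM, with a range from 50000 nM to 450000 nM.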

Compound 3, half-maximal inhibitory concentration: 209000 nM
Beside the measured number, compound 3's estimate is 1.3-fold (0.12 log units) below it, within the range that was stated.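

On a six-membered aromatic ring of carbon only, at the carbon para to a large group, fluoro in place of methoxy gives a 1.4-fold higher number from compound 2 to compound 3 (0.14 log units; within the scatter) in this assay. This first readable step shows that this swap does not separate the two compounds, so methoxy and fluoro cannot be told apart here. The step starting at compound 1 cannot be read, since its value is only a limit: the limit of > 200000 nM in this assay, at which 1 of the 3 values shown sits.

Going by these compounds, whether an amine or a carboxylic acid on that same aromatic carbon would move the number beyond the scatter remains open.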